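The compounds below may be only part of what the source reports. "The series", "measured", "known", "first", "only" and "open" are said of these compounds alone.

Measured compounds and their values:

Compound 1 (`COc1ccc(-c2c(Cl)c(=O)c3c(OC)cc(OC)cc3n2S(=O)(=O)c2ccc(OC)cc2)cc1`): in a functional assay on HepG2 cells (Homo sapiens) for antiproliferative activity, with a stated time of 72 h (a lower number here means that less compound is needed, a higher number that more compound is needed for the effect), compound 1 gives "not determined" (no result reported), that is, no result is reported.
Compound 2 (`COC(=O)c1cc(=O)c2c(OC)cc(OC)cc2[nH]1`): in this assay compound 2 gives > 34400 nM, which is a limit of the assay and not a number.
Compound 3 (`COc1ccc(-c2cc(=O)c3c(OC)cc(OC)cc3n2S(=O)(=O)c2ccc(C=O)cc2)cc1`): in this assay compound 3 gives > 34400 nM, again a limit of the assay rather than a number.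

Compound 3 therefore stands nowhere definite on the numbers shown: its result is only a limit, and the one other measured compound also stopped at a limit, so that the limit of > 34400 nM in this assay, at which 2 of the 3 values shown sit, is the only firm point the data offer. Compound 1 contributes no value at all.

The next compound, compound 4 (`COc1ccc(-c2cc(=O)c3c(OC)cc(OC)cc3n2S(=O)(=O)c2ccc(Br)cc2)cc1`), differs from compound 3 in one place: bromo in place of formyl on an aromatic carbon. Among the measured compounds shown here, no step between two measured compounds is known, so the effect of this change cannot be read from the data. Since compound 3 reached only a limit, the step to compound 4 is expected to be none beyond the scatter in this assay, with the result most likely again a limit. For compound 4 the estimate is 40000 nM, between 12000 nM and 120000 nM, which means an expected step that the limit leaves unreadable from compound 3 to compound 4.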

Compound 4, half-maximal effective concentration: 16300 nM
Compound 4: the middle estimate sits 2.5-fold (0.39 log units) above what was measured, within the range that was stated.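

Among the compounds shown here, replacing the 4-formylphenyl on the sulfonyl group with 4-bromophenyl gives the first real number in this small set, and in this assay the change amounts to an at least 2.1-fold lower number from compound 3 to compound 4 (0.32 log units; beyond the scatter). The step shows that this position, on the six-membered aromatic ring of carbon only and para to a large group, can change the read-out even though the rest of the molecule stays the same, and that a single bromine can stand where formyl stood without the result remaining at the limit. Its true size stays uncertain, since one end of the step is not a number, and the only firm point available before compound 4 was a limit: the limit of > 34400 nM in this assay, at which 2 of the 4 values shown sit.

The compounds shown leave open whether bromo itself brings the gain or whether losing formyl is enough, and the data give no reason for the step. They also leave open how an amine, a carboxylic acid or a longer chain at this same position would compare with bromo, and whether any such group could lower the number further.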